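Ethylamino to dimethylamino on a carbonyl carbon

The source may report more compounds than this note shows. Statements on the series, on what has been measured and on what is new or still open speak of the compounds shown alone.

Compound 1 `CCC(C)OC(=O)/C=C(C)/C=C/CC(C)CCCC(C)(C)OC` gives 6.49
Compound 2 `CCNC(=O)/C=C(C)/C=C/CC(C)CCCC(C)(C)OC` gives 4.04

Both numbers come from a physicochemical assay for lipophilicity (on this read-out lower numbers stand for lower lipophilicity and higher numbers for higher lipophilicity), and compound 2 holds the lower of the two. Going by the values given here, the only measured step is a number 2.45 log units lower from compound 1 to compound 2 (beyond the scatter) and it comes with ethylamino in place of sec-butoxy on a carbonyl carbon.

Compound 3 `COC(C)(C)CCCC(C)C/C=C/C(C)=C/C(=O)N(C)C` has not yet been measured. Its difference from compound 2 is dimethylamino in place of ethylamino on a carbonyl carbon and, in words, it is dimethylamino in place of ethylamino on a carbonyl carbon. The two compounds have the same atoms, joined differently.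

The measured step bears on this change only loosely. Among the compounds with values here, it shows that a swap at this carbonyl carbon can be large, but the group that left there was sec-butoxy, and no measured compound carries dimethylamino. With the atoms unchanged, a much smaller move is expected here, slightly downward and close to the scatter. In this assay the expected size is a number 0.29 log units lower from compound 2 to compound 3 (within the scatter) for this change. For compound 3 the estimate is 3.75 with an expected range from 3.3 to 4.2 at its ends.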

Compound 3, partition coefficient: 3.74
Compound 3: middle estimate off by 0.01 log units, on the high side; low and high end bracket the measured number.
By their numbers in this assay, from the lowest: compounds 3 and 2 (each within the scatter of the next); then compound 1.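

In this assay, the swap of ethylamino for dimethylamino on the carbonyl carbon gives a number 0.30 log units lower from compound 2 to compound 3 (within the scatter), so the read-out does not tell these two groups apart, although ethylamino carries a hydrogen-bond donor and dimethylamino carries none. The replacement of sec-butoxy by dimethylamino gives a number 2.75 log units lower from compound 1 to compound 3 (beyond the scatter), which means that the large step seen earlier with ethylamino is also seen with a second nitrogen-linked group at this place. No measured evidence shown here accounts for either the large step or the lack of a separable difference between the two nitrogen-linked groups.

The compounds shown leave open whether larger groups on the nitrogen, such as diethylamino or a pyrrolidine ring, or a plain amino group with no carbon substituent, would stay equally close to ethylamino and dimethylamino. They also leave open how much of the large step belongs to the exchange of oxygen for nitrogen and how much to the size of the departing chain, a question that an ester with ethoxy in place of sec-butoxy would bear on directly.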